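From 4-bromophenyl to 2-isopropylphenyl at an assay limit

The source may hold more compounds than are shown below. What is called first, only, known or untested is meant among the compounds shown, and "the series" means these compounds.

- compound 1 `COc1cc(OC)c(/C=C/C(=O)/C=C/c2cc3ccccc3nc2Cl)c(OC)c1` reads > 10000 nM as a limit
- compound 2 `COc1ccc(/C=C/C(=O)/C=C/c2cc3ccccc3nc2Oc2ccc(Br)cc2)c(OC)c1` reads > 10000 nM as a limit
- compound 3 `COc1cc(OC)c(/C=C/C(=O)/C=C/c2cc3ccccc3nc2Oc2ccc(Br)cc2)c(OC)c1` reads > 10000 nM as a limit

All three readings come from a functional assay on NCI-H460 cells (Homo sapiens) for cytotoxicity, read by MTT assay, with a stated time of 48 h (a lower number here means a stronger inhibitor, a higher number a weaker inhibitor), and each one is a limit. They sit together at the limit of > 10000 nM in this assay, at which 3 of the 3 values shown sit, with no true number among them. Compound 3 stands at > 10000 nM and this too is only a limit.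

The next structure is compound 4 `COc1cc(OC)c(/C=C/C(=O)/C=C/c2cc3ccccc3nc2Oc2ccccc2C(C)C)c(OC)c1` and it differs from compound 3 in one place, with 2-isopropylphenyl in place of 4-bromophenyl on an oxygen on an aromatic ring and the shared core unchanged.

Among the compounds with values here, two measured steps bear on this change. The more relevant one is a step that the two limits leave unreadable from compound 1 to compound 3 with 4-bromophenoxy in place of chloro on an aromatic carbon. The other is a step that the two limits leave unreadable from compound 2 to compound 3 with methoxy in place of hydrogen on an aromatic carbon. Neither gives a size to carry forward.

Given that compound 3 reads > 10000 nM as a limit, no step beyond the scatter is expected in this assay in either direction. The expected change is a step that the limit leaves unreadable from compound 3 to compound 4 and this estimate remains rough. Compound 4 is estimated at 12000 nM with an expected range from 3000 nM to 50000 nM in this test.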

Compound 4, half-maximal inhibitory concentration: > 10000 nM
Compound 4 ended at the assay's limit; the forecaster's own chance of this, stated with the estimate: 65%; the middle value does not contradict the limit.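

Compound 4 gives > 10000 nM in this assay, and this is a limit. Within the data shown here, no step from compound 3 or compound 1 to compound 4 can be read, because all these readings stop at the same point: the limit of > 10000 nM in this assay, at which 4 of the 4 values shown sit. The compounds shown leave open how strongly any of them acts on these cells, and whether 2-isopropylphenyl in place of 4-bromophenyl changes that at all.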